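Side chains on a shared core: compounds 1 to 4

The compounds below may be only part of what the source reports. "The series", "measured", "known", "first", "only" and "open" are said of these compounds alone.

Values in a functional assay on HeLa cells (Homo sapiens) for cytotoxicity, read by MTT assay; on this read-out higher numbers stand for weaker inhibition and lower numbers for stronger inhibition:
compound 1 `CCC(O)CO[C@H](CC=C(C)C)C1=CC(=O)c2c(O)ccc(O)c2C1=O`: 28700 nM
compound 2 `CC(=O)OC(C)CO[C@H](CC=C(C)C)C1=CC(=O)c2c(O)ccc(O)c2C1=O`: 40100 nM
compound 3 `CCCCC(C)(O)CC(=O)O[C@H](CC=C(C)C)C1=CC(=O)c2c(O)ccc(O)c2C1=O`: 60600 nM
not yet measured: compound 4 `CCC(CO[C@H](CC=C(C)C)C1=CC(=O)c2c(O)ccc(O)c2C1=O)OC`

The position of compound 3 is set by two steps: a 1.5-fold higher number from compound 2 to compound 3 (0.18 log units; within the scatter), and a 2.1-fold higher number from compound 1 to compound 3 (0.32 log units; beyond the scatter). The next change gives compound 4, with 2-methoxybutyl in place of (2-hydroxy-2-methylhexyl)carbonyl on an oxygen on a saturated carbon. The nearest measured comparison is compound 1, which has a 2-hydroxybutyl group on that oxygen and sits 28700 nM. Among the measured compounds shown here, the one measured change within the chain stayed small: a 1.4-fold higher number from compound 1 to compound 2 (0.15 log units; within the scatter). For the measured compounds named here, no measured step covers the methoxy group itself. The expected step in this assay is therefore a 2.0-fold lower number from compound 3 to compound 4 (0.31 log units; beyond the scatter), roughly undoing the modest step to compound 3. For compound 4 the estimated value is 30000 nM, with an expected range of 14000 nM to 62000 nM.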

Compound 4, half-maximal inhibitory concentration: 63500 nM
For compound 4 the middle estimate is 2.1-fold (0.33 log units) below the measured one; the whole stated range lies below it.
By their numbers in this assay, from the lowest: compounds 1, 2, 3 and 4 (each within the scatter of the next, the first and the last beyond it).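

In this assay, methyl in place of hydrogen on an oxygen on a saturated carbon is enough to move the number beyond the scatter (a 2.2-fold higher number from compound 1 to compound 4 (0.34 log units; beyond the scatter)). The 2-methoxybutyl group does not separate from the two other side chains, even though (2-hydroxy-2-methylhexyl)carbonyl is a larger group (a 1.0-fold higher number from compound 3 to compound 4 (0.02 log units; within the scatter); a 1.6-fold higher number from compound 2 to compound 4 (0.20 log units; within the scatter)). Nothing available here accounts for the methyl step.

Open, from the compounds shown here alone, is whether an ethoxy or propoxy group in place of the methoxy would shift the number further. Going by these compounds, an amine at that carbon is equally open.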